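The source may hold more compounds than are shown below. What is called first, only, known or untested is meant among the compounds shown, and "the series" means these compounds.

Measured compounds:
compound 1 `CCS(=O)(=O)Nc1ccc(CNC(=O)c2ccc(C(C)(C)C)cc2)c(Cl)c1`, 28 mL.min-1.g-1
compound 2 `CC(C)(C)c1ccc(C(=O)NCc2c(F)cc(NS(C)(=O)=O)cc2F)cc1`, 9.3 mL.min-1.g-1
compound 3 `COc1ccc(C(=O)NCc2ccc(NS(C)(=O)=O)cc2Cl)cc1`, 5 mL.min-1.g-1

In an ADME assay on microsomes from liver (Rattus norvegicus, strain Sprague-Dawley) for metabolic stability, read by HPLC, using NADPH, with stated times of 5 min and 60 min, tested at 10 uM (a lower number here means slower removal, a higher number faster removal of the compound), compound 3 gives 5 mL.min-1.g-1, the lowest of the three numbers. Its nearest neighbour is compound 2, whose value of 9.3 mL.min-1.g-1 lies within the usual scatter of it, so no order between these two can be claimed. Compound 1, with 28 mL.min-1.g-1, stands clearly higher, beyond the scatter.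

Compound 4 `CS(=O)(=O)Nc1ccc(CNC(=O)c2ccc(CC(F)(F)F)cc2)c(Cl)c1` has not yet been measured. It differs from compound 3 in one place: 2,2,2-trifluoroethyl in place of methoxy on an aromatic carbon. The shared core and the sulfonamide side of the molecule are unchanged.

Going by the values given here, no measured pair here isolates this exact change, so the expectation rests on the spread of the three values. Among the compounds with values here, the group that enters is larger than the one that leaves, and the one larger group seen so far, in compound 1, goes with the highest number. A modest rise in this assay is therefore expected for compound 4, though it may well stay within the scatter of compound 3; the expected step is a 1.8-fold higher number from compound 3 to compound 4 (0.26 log units; within the scatter). The estimate for compound 4 is 9 mL.min-1.g-1, with a range from 3.5 mL.min-1.g-1 to 22 mL.min-1.g-1.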

Compound 4, intrinsic clearance in microsomes: 22 mL.min-1.g-1
Compound 4: the middle estimate sits 2.4-fold (0.39 log units) below what was measured, and the stated range covers the measured number.
By their numbers in this assay, from the lowest: compounds 3 and 2 (each within the scatter of the next); then compounds 4 and 1 (each within the scatter of the next).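

Replacing methoxy with 2,2,2-trifluoroethyl, para to a large group, gives a 4.4-fold higher number from compound 3 to compound 4 (0.64 log units; beyond the scatter) in this assay, with the shared core and the sulfonamide side unchanged. Going by these compounds alone, the earlier compounds offered no pair differing in one place, so this is the only direct evidence that a change at this position alone can move the read-out beyond the scatter. Nothing available here bears on what lies behind this step.

This single step cannot separate the effect of losing methoxy from that of gaining 2,2,2-trifluoroethyl, and an ethyl, a trifluoromethyl or a hydroxyl at the same position could help to tell them apart. Going by these compounds, whether the change would give a similar step with another sulfonamide or with different substituents on the benzyl ring also remains open.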